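Adding one methyl to compound 2

This account rests on a few compounds, and the source may have more. Where it says the series, first, only, none or still open, it means among the compounds named here.

Within the data shown here, in a functional assay on HeLa cells (Homo sapiens) for antiproliferative activity, read by MTT assay, with a stated time of 48 h (a higher number here means a weaker inhibitor, a lower number a stronger inhibitor), compound 2 `O=[N+]([O-])c1ccc(-c2nn(-c3ccccc3)cc2C(Nc2nc3ccccc3s2)c2c(O)ccc3ccccc23)cc1` gives 6810 nM, the lower of the two numbers so far. With 5,6-dimethyl-1,3-benzothiazol-2-yl in place of its 1,3-benzothiazol-2-yl group, compound 1 `Cc1cc2nc(NC(c3cn(-c4ccccc4)nc3-c3ccc([N+](=O)[O-])cc3)c3c(O)ccc4ccccc34)sc2cc1C` gives 14700 nM. The unmeasured compound 3 `Cc1ccc2nc(NC(c3cn(-c4ccccc4)nc3-c3ccc([N+](=O)[O-])cc3)c3c(O)ccc4ccccc34)sc2c1` departs from compound 2 by methyl in place of hydrogen on an aromatic carbon, with methyl in place of hydrogen on an aromatic carbon, which gives 6-methyl-1,3-benzothiazol-2-yl. Among the measured compounds shown here, only one measured step bears on this change: a 2.2-fold lower number from compound 1 to compound 2 (0.33 log units; beyond the scatter), a modest step beyond the scatter. Compound 3 keeps one of the two methyl groups that this step removes, so a smaller move toward a higher number is expected in this assay. The estimated step is a 1.5-fold higher number from compound 2 to compound 3 (0.17 log units; within the scatter), which may not clear the scatter. For compound 3, the expected value is 10000 nM, with an estimated range of 5500 nM to 18000 nM.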

Compound 3, half-maximal inhibitory concentration: 7040 nM
Beside the measured number, compound 3's estimate is 1.4-fold (0.15 log units) above it; measured number inside the range.
By their numbers in this assay, from the lowest: compounds 2 and 3 (each within the scatter of the next); then compound 1.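

In this assay, the single methyl of 6-methyl-1,3-benzothiazol-2-yl leaves the number within the scatter, with a 1.0-fold higher number from compound 2 to compound 3 (0.01 log units; within the scatter). The earlier pair could not show how the change divided between the two methyl groups of 5,6-dimethyl-1,3-benzothiazol-2-yl, but among these three compounds the step beyond the scatter appears only with the methyl that compound 3 lacks, as a 2.1-fold lower number from compound 1 to compound 3 (0.32 log units; beyond the scatter). Nothing available explains why the two methyl groups differ in this way.

On these data alone, it remains open whether that other methyl would give a similar step if it stood alone on the ring. As far as these compounds go, it is also open how a methoxy group, a chlorine atom or an amine on this aromatic carbon would compare with methyl.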